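Replacing thiophen-3-yl with 3-cyanophenyl on a shared core

The compounds below may be only part of what the source reports. "The series", "measured", "known", "first", "only" and "open" are said of these compounds alone.

compound 1 `Cn1cc(-c2cc(Cl)c3ncc(Cc4ccc5ncccc5c4)n3c2)cn1`: "not determined" (no result reported)
compound 2 `Fc1cc(-c2ccsc2)cn2c(Cc3ccc4ncccc4c3)cnc12`: 444 nM

Among the measured compounds shown here, in a functional assay on EBC-1 cells (Homo sapiens) for antiproliferative activity, with a stated time of 72 h (on this read-out lower numbers stand for stronger inhibition and higher numbers for weaker inhibition), compound 2 gives 444 nM, and this is the only number available, since compound 1 comes with no numerical result ("not determined" (no result reported)). For the measured compounds named here, no ranking can therefore be drawn, and no measured step exists to serve as a guide.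

Compound 3 `N#Cc1cccc(-c2cc(F)c3ncc(Cc4ccc5ncccc5c4)n3c2)c1` keeps the core of compound 2 and differs in one place: 3-cyanophenyl in place of thiophen-3-yl on an aromatic carbon. There, 3-cyanophenyl stands in place of thiophen-3-yl on an aromatic carbon, meta to a fluoro group.

Going by the values given here, with no step to draw on, only a small move toward stronger inhibition in this assay is expected, hardly beyond the scatter, and the uncertainty is wide. The expected change is a 1.8-fold lower number from compound 2 to compound 3 (0.25 log units; within the scatter). For compound 3 the estimated value is 250 nM, with an expected range of 60 nM to 900 nM.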

Compound 3, half-maximal inhibitory concentration: 107 nM
For compound 3 the middle estimate is 2.3-fold (0.37 log units) above the measured one, within the range that was stated.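

In this assay, putting 3-cyanophenyl in place of thiophen-3-yl gives a 4.1-fold lower number from compound 2 to compound 3 (0.62 log units; beyond the scatter) and makes this aromatic carbon, meta to a fluoro group, the first position in the series where a change can be seen to move the read-out. The position therefore tolerates a six-membered aromatic ring of carbon only that bears a nitrile, with 8 heavy atoms entering where 5 leave, and inhibition is stronger with it. Nothing available on these compounds explains the step.

As far as these compounds go, whether the step belongs to the phenyl ring or to its nitrile remains open, as does the effect of moving the nitrile to give 4-cyanophenyl. It is equally unknown how a plain phenyl or a morpholine would read at this position, and compound 1, which has no numerical result, adds no comparison.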